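The source may hold more compounds than are shown below. What is called first, only, known or untested is meant among the compounds shown, and "the series" means these compounds.

Working notes on the series. The three measured compounds are compound 1 `C=C1CN(C)N(c2ccc(Cl)cc2)C1=O`, compound 2 `C=C1CN(C)N(c2ccc(Br)cc2)C1=O` and compound 3 `C=C1C(=O)N(c2ccccc2)N(C)C1c1ccc(OC)cc1`. In a functional assay on HL-60 cells (Homo sapiens) for inhibition, read by MTT assay, with a stated time of 48 h (on this read-out lower numbers stand for stronger inhibition and higher numbers for weaker inhibition), compound 1 gives 38100 nM. In this assay compound 2 gives 51800 nM, and in this assay compound 3 gives 37300 nM. Compound 2 has the highest of the three numbers, but its separation from compound 1 and from compound 3 is within the scatter, so no order among the three can be read from these values. Within the data shown here, the only single-point step among the measured compounds is a 1.4-fold higher number from compound 1 to compound 2 (0.13 log units; within the scatter), an exchange of one halogen for another that changed nothing beyond the scatter.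

Compound 4 `C=C1CN(C)N(c2ccc(C)cc2)C1=O` differs from compound 2 by methyl in place of bromo on an aromatic carbon. Among the measured compounds shown here, no measured pair in the set exchanges a halogen for methyl at this place, so the bromo-for-chloro step is the nearest guide, and it was flat. The expectation is therefore a step of no more than the scatter, with no direction, namely a 1.2-fold lower number from compound 2 to compound 4 (0.06 log units; within the scatter). On that basis compound 4 is estimated at 45000 nM in this assay, with a range from 20000 nM to 110000 nM.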

Compound 4, half-maximal inhibitory concentration: 65700 nM
Compound 4: the middle estimate sits 1.5-fold (0.16 log units) below what was measured; low and high end bracket the measured number.
By their numbers in this assay, from the lowest: compounds 3, 1, 2 and 4 (each within the scatter of the next).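

In this assay the step of a 1.3-fold higher number from compound 2 to compound 4 (0.10 log units; within the scatter) and the step of a 1.7-fold higher number from compound 1 to compound 4 (0.24 log units; within the scatter) both stay within the scatter, so this place on the aromatic ring carries methyl as well as the two halogens without any readable change. The earlier compounds shown here showed only one halogen exchanged for another; these steps extend the flat result to the exchange of a halogen for a carbon group, and compound 1, compound 2 and compound 4 cannot be put in any order by their numbers. Nothing measured here offers a reason for this flat result.

The compounds shown leave open whether this place stays flat with groups of another kind, such as a carboxylic acid, a dimethylamino group or a longer chain like butyl. They also leave open whether any group at this place can move the number beyond the scatter in either direction, and whether the same flat result would hold on a changed core.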